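Benzamido Added at the Core Carbon of Compound 3

The source may report more compounds than this note shows. Statements on the series, on what has been measured and on what is new or still open speak of the compounds shown alone.

compound 1 `CCN1CCN(CCCn2cnc3c(N4CCN(CC)CC4)nc(NCc4ccccc4)nc32)CC1` — 140 nM
compound 2 `CCN1CCN(CCCn2cnc3c(N4CCN(CC)CC4)nc(N)nc32)CC1` — 260 nM
compound 3 `CCN1CCN(CCCn2cnc3c(N4CCN(CC)CC4)ncnc32)CC1` — 1190 nM

In an assay on HEK293 cells for antagonist activity at Toll-like receptor 9 (Homo sapiens), read by spectrophotometry (a lower number here means a stronger inhibitor, a higher number a weaker inhibitor), compound 3 gives 1190 nM, the highest of the three numbers. It stands apart from both others beyond the scatter, as the step of a 4.6-fold higher number from compound 2 to compound 3 (0.66 log units; beyond the scatter) and the step of an 8.5-fold higher number from compound 1 to compound 3 (0.93 log units; beyond the scatter) show; compound 1 gives 140 nM and compound 2 gives 260 nM, and the step of a 1.9-fold higher number from compound 1 to compound 2 (0.27 log units; within the scatter) lies within the scatter.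

Compound 4 `CCN1CCN(CCCn2cnc3c(N4CCN(CC)CC4)nc(NC(=O)c4ccccc4)nc32)CC1` differs from compound 3 by benzamido in place of hydrogen on an aromatic carbon. The group brought in carries one six-membered aromatic ring of carbon only, one hydrogen-bond donor and one hydrogen-bond acceptor, and it sits on the same aromatic carbon at which compound 1 and compound 2 carry their groups. The two measured steps that bear on this change both run in the other direction: removing amino or benzylamino from that carbon raised the number modestly and beyond the scatter. Putting a donor-bearing group back there is therefore expected to lower the number, by a modest step, a 4.0-fold lower number from compound 3 to compound 4 (0.60 log units; beyond the scatter). Compound 4 is estimated at 300 nM, with a range from 100 nM to 900 nM.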

Compound 4, half-maximal inhibitory concentration: 340 nM
Compound 4: middle estimate off by 1.1-fold (0.05 log units), on the low side; measured number inside the range.
By their numbers in this assay, from the lowest: compounds 1, 2 and 4 (each within the scatter of the next, the first and the last beyond it); then compound 3.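

Benzamido on the aromatic carbon between two ring nitrogen atoms gives a 3.5-fold lower number from compound 3 to compound 4 (0.54 log units; beyond the scatter), so a lower number than with hydrogen at this carbon is not confined to amino and benzylamino, and the nitrogen attached there can carry a carbonyl. Adding benzoyl to the nitrogen of compound 2 gives a 1.3-fold higher number from compound 2 to compound 4 (0.12 log units; within the scatter), so this acylation cannot be told apart from the free amino group in this assay. Benzoyl in place of benzyl, however, gives a 2.4-fold higher number from compound 1 to compound 4 (0.39 log units; beyond the scatter), which shows that the two groups can be told apart at this nitrogen, even though compound 2 stands within the scatter of both compound 1 and compound 4.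

Nothing available here explains these steps. From the compounds shown here alone, it remains open whether acetamido, a urea or a benzamido ring carrying a carboxylic acid would fit the same picture at this carbon.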